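The compounds below may be only part of what the source reports. "The series", "measured", "known", "first", "only" and "open" are said of these compounds alone.

Compound 1 `CCOC(=O)c1c(C)nc(-c2ccc(OCC(C)C)c(C#N)c2)n1O`, compound 2 `CCOC(=O)c1c(C)nc(-c2cccc(C#N)c2)n1C` and compound 3 `CCOC(=O)c1c(C)nc(-c2cccc(C#N)c2)n1OCCC(=O)O` share one core and differ in what hangs on it. In a functional assay on a cell-free system (plasma, Oryctolagus cuniculus) for inhibition, with stated times of 5 min, 1 min and 6 min (on this read-out higher numbers stand for weaker inhibition and lower numbers for stronger inhibition), compound 1 gives 16800 nM and compound 2 gives 22100 nM. For compound 3 this assay reports only a limit, > 30000 nM, so compound 3 stands at the limit of > 30000 nM in this assay, at which 1 of the 3 values shown sits, rather than at a number. Among the measured compounds shown here, the one measured step, an at least 1.3-fold higher number from compound 2 to compound 3 (0.13 log units; that floor lies within the scatter), is itself anchored to that limit and falls within the scatter. Compound 4 `CCOC(=O)c1c(C)nc(-c2cccc(C#N)c2)n1OCc1ccc([N+](=O)[O-])cc1` differs from compound 3 by 4-nitrophenyl in place of carboxymethyl on a saturated chain carbon bound to an oxygen on an aromatic ring. For the measured compounds named here, no measured step touches a 4-nitrophenyl group, so no direction can be read off. The expected step is an at least 1.2-fold lower number from compound 3 to compound 4 (0.07 log units; that floor lies within the scatter). Compound 4 is therefore estimated at 25000 nM, between 8000 nM and 60000 nM.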

Compound 4, half-maximal inhibitory concentration: 8750 nM
Compound 4: middle estimate off by 2.9-fold (0.46 log units), on the high side; the measured number falls inside the stated range.
By their numbers in this assay, from the lowest: compounds 4, 1 and 2 (each within the scatter of the next, the first and the last beyond it). At a limit, above all of these: compound 3.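

In this assay, the group carried on the saturated chain carbon bound to an oxygen on an aromatic ring can shift the read-out: 4-nitrophenyl in place of carboxymethyl gives an at least 3.4-fold lower number from compound 3 to compound 4 (0.53 log units; beyond the scatter). Among the compounds shown here, the earlier step at this site stayed within the scatter, so this is the first change here that clearly registers. Its true size remains a floor because compound 3 has only a limit, not a number: the limit of > 30000 nM in this assay, at which 1 of the 4 values shown sits.

The compounds shown do not separate the contribution of the benzene ring from that of the nitro group, which a plain benzyl group could address. Going by these compounds, whether an amine on that ring would serve equally well also stays open.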